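The compounds below may be only part of what the source reports. "The series", "measured", "known", "first", "only" and "open" are said of these compounds alone.

Measured so far in a physicochemical assay for lipophilicity; a higher number here means a more lipophilic compound, a lower number a more polar compound:
compound 1 `CC(C)CCN(CCC(C)C)c1ccc(C(=O)N2CCc3ccc(OS(N)(=O)=O)cc3C2)cc1`: 1.93
compound 2 `CCN(Cc1ccc(Br)cc1)c1ccc(C(=O)N2CCc3ccc(OS(N)(=O)=O)cc3C2)cc1`: 1.93
compound 3 `CCN(Cc1ccc(F)cc1)c1ccc(C(=O)N2CCc3ccc(OS(N)(=O)=O)cc3C2)cc1`: 1.93

Compound 3 stands level with the other two at the digits shown: no change at the digits printed from compound 1 to compound 3 (within the scatter) and no change at the digits printed from compound 2 to compound 3 (within the scatter). Compound 4 `CCCN(Cc1ccccc1)c1ccc(C(=O)N2CCc3ccc(OS(N)(=O)=O)cc3C2)cc1` differs from compound 3 in one place: benzyl(propyl)amino in place of ethyl(4-fluorobenzyl)amino on an aromatic carbon. Within the data shown here, three measured steps bear on this. All of them swap or alter groups on the same nitrogen, and none moved the read-out beyond the scatter: no change at the digits printed from compound 1 to compound 2 (within the scatter), no change at the digits printed from compound 1 to compound 3 (within the scatter), no change at the digits printed from compound 2 to compound 3 (within the scatter). Since even a switch from two branched chains to a halogenated benzyl group left the read-out unchanged, the expected step in this assay is none beyond the scatter, no change at the digits printed from compound 3 to compound 4 (within the scatter). Compound 4 is therefore estimated at 1.93, within a range from 1.65 to 2.25.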

Compound 4, partition coefficient: 1.93
For compound 4 middle estimate and measured number coincide at the digits printed; the range from low to high includes it.
By their numbers in this assay, from the lowest: compounds 1, 2, 3 and 4 (each within the scatter of the next).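

In this assay, a benzyl group with no halogen on its ring, paired with a propyl chain instead of an ethyl chain, brings no change at the digits printed from compound 3 to compound 4 (within the scatter) on this nitrogen. The bromo-bearing amine gives the same picture, with no change at the digits printed from compound 2 to compound 4 (within the scatter) here, and the diisopentylamino group too, with no change at the digits printed from compound 1 to compound 4 (within the scatter) here. A halogen on the benzyl ring is therefore not needed to hold this level among these four compounds. No measurement offered here explains this flat result. From the compounds shown here alone, whether the level holds with a carboxylic acid on the benzyl ring, or with a morpholine as the whole amino group, stays open.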